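The source may report more compounds than this note shows. Statements on the series, on what has been measured and on what is new or still open speak of the compounds shown alone.

Compound 1 `CCCCCCCOc1c(-c2cc(OC)c(OC)c(OC)c2)oc2ccccc2c1=O` sits at the edge of the measurable range: in a functional assay on DU-145 cells (Homo sapiens) for antiproliferative activity, read by WST assay, with a stated time of 3 days (a higher number here means a weaker inhibitor, a lower number a stronger inhibitor), compound 1 gives > 50000 nM, which is a limit of the assay rather than a number (the limit of > 50000 nM in this assay, at which 1 of the 2 values shown sits). Going by the values given here, compound 2 `CCN(CC)CCCCOc1c(-c2cc(OC)c(OC)c(OC)c2)oc2ccccc2c1=O` gives 13300 nM in this assay, and the step of an at least 3.7-fold lower number from compound 1 to compound 2 (0.57 log units; beyond the scatter) is the only measured change that bears on compound 3. Compound 3 `CCCCCN(CCCCC)CCCCOc1c(-c2cc(OC)c(OC)c(OC)c2)oc2ccccc2c1=O` differs from compound 1 as follows: dipentylamino in place of propyl on a saturated chain carbon, four bonds along the chain from an oxygen on an aromatic ring. Because an amine entering at the same place produced an at least 3.7-fold lower number from compound 1 to compound 2 (0.57 log units; beyond the scatter), a step toward lower numbers is expected for compound 3, estimated at 10000 nM (range 3000 nM to 40000 nM), which means a step of an at least 5.0-fold lower number from compound 1 to compound 3 (0.69 log units; beyond the scatter).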

Compound 3, half-maximal inhibitory concentration: 12500 nM
Compound 3: the middle estimate sits 1.3-fold (0.10 log units) below what was measured, and the stated range covers the measured number.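

In this assay, the earlier drop is not confined to diethylamino: dipentylamino at the same place, four bonds along the chain from the oxygen, gives an at least 4.0-fold lower number from compound 1 to compound 3 (0.60 log units; beyond the scatter). The two amines cannot be told apart in this assay, with a 1.1-fold lower number from compound 2 to compound 3 (0.03 log units; within the scatter). The value for compound 1 is a limit of the assay and not a number: the limit of > 50000 nM in this assay, at which 1 of the 3 values shown sits.

Going by these compounds, whether dimethylamino or a cyclic amine such as piperidine would fit this pattern remains open. So does the effect of a shorter or longer chain between the oxygen and the nitrogen.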